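Weak Binders Around a Hindered Phenol Amide

A few compounds are considered here, and "the series" means these few. Any claim that something is new, unique, unknown or untested is made for them only; others in the source may bear on it.

Compound 1: `CC(C)(C)c1cc(C(=O)NCCC2CCN(Cc3ccccc3)CC2)cc(C(C)(C)C)c1O` — 109000 nM
Compound 2: `CC(C)(C)c1cc(CCC(=O)NC2CCN(Cc3ccccc3)CC2)cc(C(C)(C)C)c1O` — 90200 nM
Compound 3: `COc1ccc(CN2CCC(CCNC(=O)/C=C/c3cc(C(C)(C)C)c(O)c(C(C)(C)C)c3)CC2)cc1` — 72500 nM

Of the compounds shown here, three have been measured in an assay on isolated protein for inhibition of Amine oxidase [flavin-containing] A (Homo sapiens), read by fluorescence, with stated times of 15 min and 20 min; a higher number here means a weaker inhibitor, a lower number a stronger inhibitor. In this assay compound 1 gives 109000 nM, compound 2 gives 90200 nM and compound 3 gives 72500 nM. Compound 3 carries the lowest of the three numbers, yet its gap to compound 2 and its gap to compound 1 both lie within the scatter of repeated measurements, so no order among the three can be read from these values, and none of them can be called the strongest or weakest.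

Compound 4, `CC(C)(C)c1cc(/C=C/C(=O)NCCC2CCN(Cc3ccc(F)c(F)c3)CC2)cc(C(C)(C)C)c1O`, has not yet been measured in this assay. It differs from compound 3 in one place: 3,4-difluorophenyl in place of 4-methoxyphenyl on a saturated chain carbon bound to an amine nitrogen in a ring. Going by the values given here, no pair of measured compounds differing in a single place is available, so the size of this step has no precedent in the set. Because compound 3 gives 72500 nM and the three measured values sit so close together, the author expects the change to stay within the scatter, with no clear direction. For compound 4 the estimate is 65000 nM, between 25000 nM and 160000 nM. The expected step from compound 3 to compound 4 is therefore a 1.1-fold lower number from compound 3 to compound 4 (0.05 log units; within the scatter), essentially flat.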

Compound 4, half-maximal inhibitory concentration: 64500 nM
Compound 4: the middle estimate sits 1.0-fold (0.00 log units) above what was measured; measured number inside the range.
By their numbers in this assay, from the lowest: compounds 4, 3, 2 and 1 (each within the scatter of the next).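

In this assay, the exchange of 4-methoxyphenyl for 3,4-difluorophenyl on a saturated chain carbon bound to an amine nitrogen in a ring gives the set its first comparison of compounds differing in one place: a 1.1-fold lower number from compound 3 to compound 4 (0.05 log units; within the scatter). At this position, then, replacing a group with 1 hydrogen-bond acceptor by one with 0, at 8 heavy atoms on each side, does not move the number beyond the scatter, so this pair shows no sensitivity to this particular change. No supporting data are available to explain the size of this step.

From the compounds shown here alone, what a pyridine ring or a phenyl ring carrying a carboxylic acid would do at this position remains open, so a single exchange cannot show whether the position tolerates every change or only this one. Compound 1 and compound 2 each differ from compound 3 in more than one place, which leaves the contribution of the chain joining the amide to the rest of the molecule unresolved as well.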